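Aryl amide variation on the shared core: antiproliferative notes

The compounds below may be only part of what the source reports. "The series", "measured", "known", "first", "only" and "open" are said of these compounds alone.

Measured compounds in a functional assay on MCF7 cells (Homo sapiens) for antiproliferative activity, read by CCK-8 assay, with a stated time of 72 h; on this read-out lower numbers stand for stronger inhibition and higher numbers for weaker inhibition:
- compound 1 `O=C(Nc1cccc(-c2oc3cc(-c4ccc(F)cc4)ccc3c(=O)c2O)c1)c1ccccc1F`: 7570 nM
- compound 2 `Cc1ccc(C(=O)Nc2cccc(-c3oc4cc(-c5ccc(F)cc5)ccc4c(=O)c3O)c2)cc1`: 2400 nM
- compound 3 `COc1ccccc1C(=O)Nc1cccc(-c2oc3cc(-c4ccc(F)cc4)ccc3c(=O)c2O)c1`: 2100 nM

Compound 3 gives the lowest number of the three in this assay. Its nearest neighbour is compound 2, and the gap a 1.1-fold lower number from compound 2 to compound 3 (0.06 log units; within the scatter) lies within the scatter, so the two cannot be ordered. Compound 1 stands apart: a 3.6-fold lower number from compound 1 to compound 3 (0.56 log units; beyond the scatter) and a 3.2-fold lower number from compound 1 to compound 2 (0.50 log units; beyond the scatter) are both beyond the scatter and of modest size.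

Compound 4 `O=C(Nc1cccc(-c2oc3cc(-c4ccc(F)cc4)ccc3c(=O)c2O)c1)c1ccc(Br)cc1` is not yet measured. It differs from compound 3 in one place: 4-bromophenyl in place of 2-methoxyphenyl on a carbonyl carbon. Among the measured compounds shown here, no measured step exchanges a 2-methoxyphenyl for a 4-bromophenyl. For the measured compounds named here, the steps that bear on it are indirect. The move from compound 1 to compound 2, a 2-fluorophenyl to a 4-methylphenyl, gave a 3.2-fold lower number from compound 1 to compound 2 (0.50 log units; beyond the scatter); the move from compound 2 to compound 3 gave a 1.1-fold lower number from compound 2 to compound 3 (0.06 log units; within the scatter), within the scatter. Compounds 2 and 3 thus sit together, and compound 4 carries a 4-bromophenyl, a single ring with one substituent like compound 2.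

The expectation for compound 4 in this assay is a number close to compound 2 and compound 3, with a step of a 1.2-fold higher number from compound 3 to compound 4 (0.08 log units; within the scatter) that is not expected to exceed the scatter. The estimate for compound 4 is 2500 nM, ranging from 1000 nM to 6000 nM.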

Compound 4, half-maximal inhibitory concentration: 24000 nM
For compound 4 the middle estimate is 9.6-fold (0.98 log units) below the measured one; the measured number lies above the stated range.
By their numbers in this assay, from the lowest: compounds 3 and 2 (each within the scatter of the next); then compound 1; then compound 4.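

In this assay, the aryl group on the carbonyl carbon can shift the number much further than the first three compounds suggested, with an 11-fold higher number from compound 3 to compound 4 (1.06 log units; beyond the scatter) and a 10-fold higher number from compound 2 to compound 4 (1.00 log units; beyond the scatter). The second of these steps is only bromo in place of methyl on an aromatic carbon, and with a 3.2-fold higher number from compound 1 to compound 4 (0.50 log units; beyond the scatter) the earlier high end of the series is passed as well, so carrying one substituent on the ring does not by itself place a compound with the low-number pair. No measured property of these compounds bears on this jump, and the data give no reason for it.

On these data alone, whether a 4-chlorophenyl or a 4-methoxyphenyl on the same carbonyl carbon would sit with the low-number pair or with compound 4 remains open, and so does whether the high number belongs to bromo alone. Also open, as far as these compounds go, is how a ring bearing an amine or a carboxylic acid, or a longer alkyl chain in place of the aryl ring, would read out in this assay.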